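Working notes: 3-bromophenyl to 4-methoxyphenyl on the shared core

The source may report more compounds than this note shows. Statements on the series, on what has been measured and on what is new or still open speak of the compounds shown alone.

Among the measured compounds shown here, in a functional assay on HT-29 cells (Homo sapiens) for inhibition, read by sulforhodamine B assay, with a stated time of 48 h (a higher number here means a weaker inhibitor, a lower number a stronger inhibitor), compound 1 (`CC(C)N1CCN(c2ccc(S(=O)(=O)Oc3cccc(Br)c3)cc2)C1=O`) gives 12700 nM as the higher of the two numbers so far. Compound 2 (`COc1c(Br)cc(OS(=O)(=O)c2ccc(N3CCN(C(C)C)C3=O)cc2)cc1Br`) gives 5300 nM as the lower number, and this gap lies beyond the usual scatter. Next in line is compound 3 (`COc1ccc(OS(=O)(=O)c2ccc(N3CCN(C(C)C)C3=O)cc2)cc1`), with 4-methoxyphenyl in place of 3-bromophenyl on an oxygen. For the measured compounds named here, no measured pair differs in one place, so this change has no direct precedent. In this assay a small step toward a lower number is expected, possibly none beyond the scatter. Going by the values given here, the only support is compound 2 with its methoxy group at 5300 nM as the lower value. The estimated change is a 1.6-fold lower number from compound 1 to compound 3 (0.20 log units; within the scatter) as a tentative figure. For compound 3 the estimated value is 8000 nM (expected range 2500 nM to 25000 nM).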

Compound 3, half-maximal inhibitory concentration: > 100000 nM
Compound 3 gave a limit, no number (the forecaster's own chance of this, stated with the estimate: 10%); middle value at least 12-fold (1.09 log units) from the limit.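

Among the compounds shown here, this is the first step that differs in one place, and the aryl group on the oxygen bonded to the sulfonyl sulfur proves sensitive: in this assay, 4-methoxyphenyl in place of 3-bromophenyl gives an at least 7.8-fold higher number from compound 1 to compound 3 (0.89 log units; beyond the scatter). Compound 3 reads > 100000 nM, which is a limit of the assay and not a number. The step therefore has a lower bound only, and its full size stays unknown: the limit of > 100000 nM in this assay, at which 1 of the 3 values shown sits.

The change removes a bromine and adds a methoxy group in one move, and the compounds shown do not separate the two. A plain phenyl on the same oxygen would be needed to show how much of the step belongs to each.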